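The source may hold more compounds than are shown below. What is called first, only, known or untested is meant among the compounds shown, and "the series" means these compounds.

Working notes on the series in a functional assay on HT-29 cells (Homo sapiens) for antiproliferative activity, read by MTT assay, with a stated time of 72 h; on this read-out higher numbers stand for weaker inhibition and lower numbers for stronger inhibition.

Three members of the series carry the same core and differ only in the amine at the end of the side chain. Compound 1 `COc1cc2c(Oc3c(F)cc(NC(=O)NN4C(=O)CSC4c4c(F)cccc4F)cc3F)ccnc2cc1OCCCN1CCCC1` gives 230 nM in this assay. Compound 2 `COc1cc2c(Oc3c(F)cc(NC(=O)NN4C(=O)CSC4c4c(F)cccc4F)cc3F)ccnc2cc1OCCCN1CCN(C)CC1` gives 150 nM in this assay, and the step of a 1.5-fold lower number from compound 1 to compound 2 (0.19 log units; within the scatter) lies within the scatter. Compound 3 `COc1cc2c(Oc3c(F)cc(NC(=O)NN4C(=O)CSC4c4c(F)cccc4F)cc3F)ccnc2cc1OCCCN1C[C@H]2CCCC[C@H]2C1` gives 470 nM in this assay, the highest of the three numbers: the steps of a 2.0-fold higher number from compound 1 to compound 3 (0.31 log units; beyond the scatter) and a 3.1-fold higher number from compound 2 to compound 3 (0.50 log units; beyond the scatter) both run upward and beyond the scatter.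

Compound 4 `CCN1CCN(CCCCOc2cc3nccc(Oc4c(F)cc(NC(=O)NN5C(=O)CSC5c5c(F)cccc5F)cc4F)c3cc2OC)CC1` is not yet measured in this assay. It is obtained from compound 3 by a group of 9 heavy atoms (7 carbon, 2 nitrogen; one six-membered non-aromatic ring with 2 hetero atoms) in place of a group of 9 heavy atoms (8 carbon, 1 nitrogen; one five-membered non-aromatic ring with 1 hetero atom, one six-membered non-aromatic ring of carbon only), on a saturated chain carbon, three bonds along the chain from an oxygen on an aromatic ring. The step that bears on it most directly is a 3.1-fold higher number from compound 2 to compound 3 (0.50 log units; beyond the scatter), which exchanged a six-membered ring with two hetero atoms for the bicyclic amine; compound 4 reverses that exchange, adding one carbon to the substituent on the second ring nitrogen. The step of a 2.0-fold higher number from compound 1 to compound 3 (0.31 log units; beyond the scatter) points the same way. A downward step is therefore expected, of a size near the reversal of the earlier one, a 2.9-fold lower number from compound 3 to compound 4 (0.47 log units; beyond the scatter). Compound 4 is expected at 160 nM in this assay, within 80 nM to 350 nM.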

Compound 4, half-maximal inhibitory concentration: 830 nM
Compound 4: the middle estimate sits 5.2-fold (0.71 log units) below what was measured; measured number above the stated range.
By their numbers in this assay, from the lowest: compounds 2 and 1 (each within the scatter of the next); then compounds 3 and 4 (each within the scatter of the next).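

In this assay, a piperazine ring at this place does not by itself keep the number low: a 5.5-fold higher number from compound 2 to compound 4 (0.74 log units; beyond the scatter) is beyond the scatter and is the largest step in the set, and it comes with (4-ethylpiperazin-1-yl)methyl in place of 4-methylpiperazin-1-yl on the saturated chain carbon. a 3.6-fold higher number from compound 1 to compound 4 (0.56 log units; beyond the scatter) is also beyond the scatter, while a 1.8-fold higher number from compound 3 to compound 4 (0.25 log units; within the scatter) lies within it, so compound 4 groups with the bicyclic amine of compound 3 rather than with compound 1 or compound 2, and the kind of ring alone does not sort these four compounds. No measurement at hand explains this result.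

The step from compound 2 to compound 4 joins two alterations, the methyl link in the entering group and ethyl in place of methyl on the piperazine, and the compounds shown cannot tell which of them carries the step. A 4-ethylpiperazin-1-yl group or a (4-methylpiperazin-1-yl)methyl group at this place would separate the two.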